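Aminoquinoline ethers: permeability notes toward a naphthyl analogue

A few compounds are considered here, and "the series" means these few. Any claim that something is new, unique, unknown or untested is made for them only; others in the source may bear on it.

Measured so far:
compound 1, `COc1cccc(Oc2ccc3c(NCCCNCc4cc(F)ccc4OC)ccnc3c2)c1`, 317 10^-6 cm/s
compound 2, `COc1ccc(Oc2ccc3c(NCCCNCc4cccc(OC)c4O)ccnc3c2)cc1`, 317 10^-6 cm/s
compound 3, `COc1cccc(Oc2ccc3c(NCCCNCc4cccc(OC)c4O)ccnc3c2)c1`, 317 10^-6 cm/s

In an ADME assay for permeability, using PAMPA, with a stated time of 30 min, at pH 7.4 (a higher number here means that the compound crosses the layer faster, a lower number that the compound crosses the layer more slowly), compound 1 gives 317 10^-6 cm/s, compound 2 gives 317 10^-6 cm/s and compound 3 gives 317 10^-6 cm/s. Compound 3 sits level with both neighbours: the step of no change at the digits printed from compound 1 to compound 3 (within the scatter) and the step of no change at the digits printed from compound 2 to compound 3 (within the scatter) both stay within the scatter, so nothing in this set separates one compound from another.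

Compound 4 is `COc1cccc(CNCCCNc2ccnc3cc(-c4cccc5ccccc45)ccc23)c1O`. It differs from compound 3 in one place: naphthalen-1-yl in place of 3-methoxyphenoxy on an aromatic carbon. Of the two measured steps, no change at the digits printed from compound 2 to compound 3 (within the scatter) is the one that touches the same position, since it also alters the group on that aromatic carbon of the shared core, and it produced no change. The step of no change at the digits printed from compound 1 to compound 3 (within the scatter) concerns a different part of the molecule and likewise showed nothing. Within the data shown here, no measured step swaps an aryl ether for a directly bonded aryl ring, so the present change goes beyond what the series covers. Given that both recorded steps are flat, the working expectation for compound 4 in this assay is a step of a 1.1-fold lower number from compound 3 to compound 4 (0.02 log units; within the scatter), that is, no movement beyond the scatter. Compound 4 is therefore estimated at 300 10^-6 cm/s, with a range from 150 10^-6 cm/s to 450 10^-6 cm/s.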

Compound 4, apparent permeability: 237 10^-6 cm/s
The estimate for compound 4 lay 1.3-fold (0.10 log units) above the measured number, within the range that was stated.
By their numbers in this assay, from the lowest: compounds 4, 1, 2 and 3 (each within the scatter of the next).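

Among these compounds, at this aromatic carbon of the shared core, the earlier compounds varied only the placement of methoxy on a phenoxy group, whereas compound 4 replaces the whole aryl ether with a directly bonded aryl ring. In this assay this gives a 1.3-fold lower number from compound 3 to compound 4 (0.13 log units; within the scatter) and also a 1.3-fold lower number from compound 2 to compound 4 (0.13 log units; within the scatter), so a group with no oxygen and two carbon rings reads the same, within the scatter, as either methoxyphenoxy group. Nothing shown accounts for how these numbers arise.

Going by these compounds, whether an amine or a carboxylic acid on this aromatic carbon would move the number beyond the scatter remains open. Naphthalen-1-yl also appears only alongside 2-hydroxy-3-methoxyphenyl, so its pairing with 5-fluoro-2-methoxyphenyl is equally unresolved.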